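A few compounds are considered here, and "the series" means these few. Any claim that something is new, unique, unknown or untested is made for them only; others in the source may bear on it.

Working notes on the series in a functional assay on A549 cells (Homo sapiens) for antiproliferative activity, read by MTT assay, with a stated time of 72 h; on this read-out lower numbers stand for stronger inhibition and higher numbers for weaker inhibition. Compound 1 `COc1cc(-c2ncnn2-c2ccc([N+](=O)[O-])cc2)cc(OC)c1OC` gives > 10000 nM, which is a limit and not a number. Compound 2 `COc1cc(-c2ncnn2-c2ccc(N)cc2)cc(OC)c1OC` gives > 10000 nM, again only a limit, so its place in the series has no numerical reading. Both measured compounds share this position: the limit of > 10000 nM in this assay, at which 2 of the 2 values shown sit. Going by the values given here, the one measured step is a step that the two limits leave unreadable from compound 1 to compound 2, and it supplies neither a size nor a direction to carry forward.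

Compound 3 `COc1cc(-c2ncnn2-c2ccc(Cl)cc2)cc(OC)c1OC` has chloro in place of amino on an aromatic carbon, para to a large group: chloro in place of amino on an aromatic carbon. With only a step that the two limits leave unreadable from compound 1 to compound 2 to go on, no clear gain or loss is expected, and a further limit reading is the likeliest outcome. The estimated change is a number no higher from compound 2 to compound 3 (the limit leaves the size open), with no firm direction expected. In this assay the expected value for compound 3 is 10000 nM, within an estimated range of 2000 nM to 30000 nM.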

Compound 3, half-maximal inhibitory concentration: > 10000 nM
Compound 3 gave a limit, no number; the forecaster's own chance of this, stated with the estimate: 70%; the middle value sits exactly at the limit.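

In this assay compound 3 gives > 10000 nM, a limit and not a number. No step from compound 1 or compound 2 to compound 3 can be read: the limit of > 10000 nM in this assay, at which 3 of the 3 values shown sit.

The compounds shown leave open whether any group at this place gives a readable number in this assay.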